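The source may report more compounds than this note shows. Statements on the series, on what has been measured and on what is new or still open speak of the compounds shown alone.

Compound 1 `CCc1ccc(Nc2cc(NC(=O)Nc3cc(OC)cc(OC)c3)ncn2)cc1` and compound 2 `Cc1ccc(Nc2cc(NC(=O)Nc3c(Cl)cccc3Cl)ncn2)cc1C` share a core and were both tested in a functional assay on PC-9 cells (Homo sapiens) for inhibition, read by MTT assay, with a stated time of 48 h, tested at 10 uM; a higher number here means more inhibition at the concentration tested (going by the name of the read-out), a lower number less inhibition. In this assay compound 1 gives 78%, the lower of the two numbers, while compound 2 gives 92.1%, a value beyond the scatter above it. Compound 3 `COc1cc(NC(=O)Nc2cc(Nc3ccc(C)c(F)c3)ncn2)cc(OC)c1` has not yet been tested in this assay. It differs from compound 1 in one place: 3-fluoro-4-methylphenyl in place of 4-ethylphenyl on a nitrogen on an aromatic ring. For the measured compounds named here, no measured pair shows this change, so only a small effect is expected, with an estimated step of no change at the digits printed from compound 1 to compound 3 (within the scatter), none beyond the scatter. Compound 3 is accordingly expected to give 78%, within 62% to 90%.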

Compound 3, a percentage reported as inhibition, at one concentration (the size of the read-out at that concentration, not a potency): 77.5%
Estimate against measurement, compound 3: 0.5 percentage points above; measured number inside the range.
By their numbers in this assay, from the lowest: compounds 3 and 1 (each within the scatter of the next); then compound 2.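

In this assay, for the compounds shown here, the step of a number 0.5 percentage points lower from compound 1 to compound 3 (within the scatter) is the first reading for a single change, showing that 3-fluoro-4-methylphenyl can take the place of 4-ethylphenyl on a nitrogen on an aromatic ring while the number stays within the scatter. Compound 1 and compound 2 differ in more than one place, so that pair could not isolate this position. No evidence bears on why this exchange behaves as it does. From the compounds shown here alone, whether an amine or a carboxylic acid on this phenyl ring would hold the number stays open. So does whether the same exchange would give a similar step on the core of compound 2.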